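Methyl on the hydroxy oxygen of compound 2

A few compounds are considered here, and "the series" means these few. Any claim that something is new, unique, unknown or untested is made for them only; others in the source may bear on it.

- Compound 1 `O=C(NO)c1cc2ccn(Cc3ccc(Cl)s3)c2cn1`: > 10000 nM, a limit of the assay
- Compound 2 `CN(O)C(=O)c1cc2ccn(Cc3ccc(F)cc3F)c2cn1`: 135000 nM

Among the measured compounds shown here, in an ADME assay on CEM-SS cells (Homo sapiens) for cytotoxicity, read by XTT assay (a higher number here means that more compound is tolerated, a lower number that less compound is tolerated), compound 2 gives 135000 nM, the only actual number so far. Compound 1 gives > 10000 nM, which is a limit and not a number. With a single number, compound 2 cannot yet be ranked against anything.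

Compound 3 `CON(C)C(=O)c1cc2ccn(Cc3ccc(F)cc3F)c2cn1` differs from compound 2 in one place: methyl in place of hydrogen on an oxygen. This puts methyl in place of hydrogen on an oxygen, so hydroxy(methyl)carbamoyl becomes methoxy(methyl)carbamoyl.

For the measured compounds named here, no measured pair of compounds shows what this change does in this assay. The working expectation is therefore no shift beyond the usual scatter, in either direction. The expected size of the change is a 1.0-fold higher number from compound 2 to compound 3 (0.02 log units; within the scatter). For compound 3 the estimated value is 140000 nM, within an expected range of 60000 nM to 320000 nM.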

Compound 3, half-maximal cytotoxic concentration: > 10000 nM
Compound 3 was reported as a limit; the forecaster's own chance of this, stated with the estimate: 40%; the middle value lies beyond the limit too.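

In this assay compound 3 gives > 10000 nM, which is a limit and not a number, so the change from compound 2 to compound 3 has no readable size. The compounds shown leave open whether going from hydroxy(methyl)carbamoyl to methoxy(methyl)carbamoyl shifts the tolerated concentration at all, or in which direction.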